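Swapping the ring-nitrogen substituent of compound 3

This account rests on a few compounds, and the source may have more. Where it says the series, first, only, none or still open, it means among the compounds named here.

Measured compounds:
compound 1 `Cn1cnnc1SCC(=O)Nc1ccc(-c2nc(-c3ccccc3)c(-c3ccccc3)n2C)cc1` — 59.2%
compound 2 `Cn1ccnc1SCC(=O)Nc1ccc(-c2nc(-c3ccccc3)c(-c3ccccc3)n2C)cc1` — 27.2%
compound 3 `CN(C)/C=C/N1CCN(CC(=O)Nc2ccc(-c3nc(-c4ccccc4)c(-c4ccccc4)n3C)cc2)CC1` — 11.1%

In a functional assay on MCF7 cells (Homo sapiens) for cytotoxicity, read by MTT assay, with a stated time of 24 h, tested at 6.4 ug/mL (on this read-out lower numbers stand for a weaker effect and higher numbers for a stronger effect at the one concentration tested), compound 3 stands lowest of the three, below compound 2 by a number 16.1 percentage points lower from compound 2 to compound 3 (beyond the scatter) and below compound 1 by a number 48.1 percentage points lower from compound 1 to compound 3 (beyond the scatter). Compound 4 `Cn1c(-c2ccc(NC(=O)CN3CCN(c4ccccc4)CC3)cc2)nc(-c2ccccc2)c1-c1ccccc1` keeps the shared core and differs from compound 3 only in phenyl in place of 2-(dimethylamino)ethenyl on an amine nitrogen in a ring, giving 4-phenylpiperazin-1-yl. Among the compounds with values here, no measured step alters this amine nitrogen in a ring; the known steps, a number 32 percentage points lower from compound 1 to compound 2 (beyond the scatter) and the two into compound 3, all change the sulfur-linked group instead, so they offer no direct guide. With nothing to support a large shift, compound 4 is expected to stay near compound 3, estimated at 20% (range 5% to 45%), a step of a number 8.9 percentage points higher from compound 3 to compound 4 (within the scatter).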

Compound 4, a percentage reported as activity, at one concentration (the size of the read-out at that concentration, not a potency): 37.7%
The estimate for compound 4 lay 17.7 percentage points below the measured number, within the range that was stated.
By their numbers in this assay, from the lowest: compound 3; then compound 2; then compound 4; then compound 1.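

In this assay, within the data shown here, the amine nitrogen in a ring is changed for the first time, and phenyl in place of 2-(dimethylamino)ethenyl gives a number 26.6 percentage points higher from compound 3 to compound 4 (beyond the scatter) on that read-out, so this position does affect the result. The 4-phenylpiperazin-1-yl group also compares well with the (1-methyl-1H-imidazol-2-yl)sulfanyl group, with a number 10.5 percentage points higher from compound 2 to compound 4 (beyond the scatter) in its favour, but it falls short of the (4-methyl-4H-1,2,4-triazol-3-yl)sulfanyl group, with a number 21.5 percentage points lower from compound 1 to compound 4 (beyond the scatter) as the gap. As far as these compounds go, whether a benzyl group or a chlorophenyl group on this nitrogen would go further remains open. No evidence is available to explain these steps.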